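Swapping the pyrrole for a methoxyphenyl in a cyanoacrylamide

The source may report more compounds than this note shows. Statements on the series, on what has been measured and on what is new or still open speak of the compounds shown alone.

The study covers three compounds sharing an acrylonitrile chain. Compound 1 `N#C/C(=C\c1c(F)c(F)c(F)c(F)c1F)C(=O)c1ccc[nH]1` carries a pentafluorophenyl group on the chain and a pyrrole on the carbonyl side; in a functional assay on HT-29 cells (Homo sapiens) for inhibition, read by MTT assay, with a stated time of 72 h (a higher number here means a weaker inhibitor of growth, a lower number a stronger inhibitor of growth), compound 1 gives 224000 nM. Compound 2 `N#C/C(=C\c1ccc[nH]1)C(=O)NCc1ccc(Cl)c(Cl)c1` carries the pyrrole on the chain and a dichlorobenzylamide on the carbonyl side; in this assay compound 2 gives 85000 nM. Of the two measured values, compound 2 has the lower number, and its gap to compound 1 lies beyond the scatter.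

Compound 3 `COc1ccc(/C=C(\C#N)C(=O)NCc2ccc(Cl)c(Cl)c2)cc1` has not yet been measured. It differs from compound 2 in one place: 4-methoxyphenyl in place of 1H-pyrrol-2-yl on a double-bonded chain carbon bound to a double-bonded chain carbon. Among the compounds with values here, no step between measured compounds isolates this change, so no measured reference exists for it. Within the data shown here, because compound 2 gives 85000 nM and both compounds measured so far sit in the weak range, compound 3 is expected to stay in a similar range, and the step of a 1.2-fold lower number from compound 2 to compound 3 (0.08 log units; within the scatter) is expected to be none beyond the scatter. Compound 3 is therefore estimated at 70000 nM, within 15000 nM to 300000 nM.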

Compound 3, concentration for 50% growth inhibition: > 100000 nM
Compound 3 gave a limit, no number; the forecaster's own chance of this, stated with the estimate: 10%; middle value at least 1.4-fold (0.15 log units) from the limit.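

In this assay compound 3 gives > 100000 nM, which is a limit of the assay and not a number. Within the data shown here, with the dichlorobenzylamide held constant, placing 4-methoxyphenyl in place of 1H-pyrrol-2-yl on a double-bonded chain carbon bound to a double-bonded chain carbon gives an at least 1.1-fold higher number from compound 2 to compound 3 (0.07 log units; that floor lies within the scatter), the first step in this set to isolate a single change at this place. The exchange, which replaces a group with 1 hydrogen-bond donor and 0 hydrogen-bond acceptors by one with 0 hydrogen-bond donors and 1 hydrogen-bond acceptor, brings no gain in growth inhibition, but the size of any loss cannot be read, and only a floor within the scatter can be given for it: the limit of > 100000 nM in this assay, at which 1 of the 3 values shown sits.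

The data leave open how far compound 3 really lies from compound 2, and so whether the change matters at all at this place. They also leave open whether a 4-hydroxyphenyl group or an imidazole ring at this place would give a measurable number, which would help separate the effect of the hydrogen-bond donor from that of the ring itself.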